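Second Chloro Added to a Carbamate Pair Level in Inhibition

A few compounds are considered here, and "the series" means these few. Any claim that something is new, unique, unknown or untested is made for them only; others in the source may bear on it.

In a functional assay on PANC-1 cells (Homo sapiens) for inhibition, read by MTT assay, with a stated time of 24 h, tested at 10 uM (on this read-out lower numbers stand for less inhibition and higher numbers for more inhibition at the one concentration tested (going by the name of the read-out)), compound 1 `COc1ccccc1NC(=O)Oc1cc(=O)n(CCCO)c2c1CC(CC=C(C)C)C(C)(C)C2` gives 0%. Compound 2 `CC(C)=CCC1Cc2c(OC(=O)Nc3ccc(Cl)cc3)cc(=O)n(CCCO)c2CC1(C)C` gives 0%, so compound 2 stands level with compound 1, and the step of no change at the digits printed from compound 1 to compound 2 (within the scatter) lies within the scatter. Compound 3 `CC(C)=CCC1Cc2c(OC(=O)Nc3ccc(Cl)c(Cl)c3)cc(=O)n(CCCO)c2CC1(C)C` differs from compound 2 by chloro in place of hydrogen on an aromatic carbon. Going by the values given here, only one measured step bears on this change, and since the step of no change at the digits printed from compound 1 to compound 2 (within the scatter) showed nothing beyond the scatter when the ring substituent was swapped, the step of a number 2 percentage points higher from compound 2 to compound 3 (within the scatter) is expected to stay within the scatter as well. Compound 3 is therefore estimated at 2%, with a range from -8% to 15%.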

Compound 3, a percentage reported as inhibition, at one concentration (the size of the read-out at that concentration, not a potency): 1.8%
Estimate against measurement, compound 3: 0.2 percentage points above, and the stated range covers the measured number.
By their numbers in this assay, from the lowest: compounds 1, 2 and 3 (each within the scatter of the next).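

In this assay, the 3,4-dichlorophenyl group gives a number 1.8 percentage points higher from compound 2 to compound 3 (within the scatter), so a chloro on this aromatic carbon, ortho to the first chloro, leaves the reading level with that of the 4-chlorophenyl group. Set against the 2-methoxyphenyl group, the same change gives a number 1.8 percentage points higher from compound 1 to compound 3 (within the scatter), so all three substituted phenyl groups read alike at this one concentration. No supporting data bear on why these readings stay level. From the compounds shown here alone, whether an amine or a carboxylic acid on this ring would carry the number beyond the scatter stays open. Going by these compounds, how these compounds would read at other concentrations also stays open.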